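Amide series: the step from compound 3 to compound 4

The compounds below may be only part of what the source reports. "The series", "measured", "known", "first", "only" and "open" are said of these compounds alone.

Measured so far:
- compound 1 `O=C(Nc1ccc(Oc2ccnc3[nH]ccc23)cc1)c1cn(-c2ccc(F)cc2)c2ccccc2c1=O`: 720 nM
- compound 2 `O=C(Nc1ccc(Oc2ccnc3[nH]ccc23)cc1)c1cn(-c2ccc(Br)cc2F)c2ccccc2c1=O`: "not determined" (no result reported)
- compound 3 `Cn1ccc2c(Oc3ccc(NC(=O)c4cn(-c5ccc(F)cc5)c5ccccc5c4=O)cc3F)ccnc21`: "not determined" (no result reported)

For the measured compounds named here, in a functional assay on MCF7 cells (Homo sapiens) for inhibition, read by MTT assay, with a stated time of 72 h (a lower number here means a stronger inhibitor, a higher number a weaker inhibitor), compound 1 gives 720 nM and is the only compound with a number. In this assay compound 2 gives "not determined" (no result reported), so no number stands for it. In this assay compound 3 gives "not determined" (no result reported); compound 3 therefore has no single number of its own, and one further entry in the series, compound 2, is in the same position. Nothing can be said about where compound 3 sits relative to compound 1 on the numbers shown.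

Compound 4 `Cn1ccc2c(Oc3ccc(NC(=O)c4cn(-c5ccc(C(F)(F)F)cc5Cl)c5ccccc5c4=O)cc3F)ccnc21` is not yet measured. It differs from compound 3 in one place: 2-chloro-4-(trifluoromethyl)phenyl in place of 4-fluorophenyl on an aromatic nitrogen. Going by the values given here, no step between measured compounds covers a change at this position, and compound 3 itself carries no number, so the size and direction of the step to compound 4 in this assay cannot be read from the series. Among the compounds with values here, the only anchor is the value of compound 1.

Compound 4 is expected in this assay near 900 nM, with a range from 150 nM to 5000 nM.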

Compound 4, half-maximal inhibitory concentration: 190 nM
Beside the measured number, compound 4's estimate is 4.7-fold (0.68 log units) above it; low and high end bracket the measured number.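

In this assay, for the compounds shown here, compound 4 gives 190 nM but compound 3 has no number, so no step from compound 3 to compound 4 can be read. The compounds shown leave open what 2-chloro-4-(trifluoromethyl)phenyl in place of 4-fluorophenyl does to the value in this series. No evidence shown here bears on this result.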